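The compounds below may be only part of what the source reports. "The series", "measured", "known", "first", "only" and "open" are said of these compounds alone.

Three compounds have been measured in an ADME assay on HaCaT cells (Homo sapiens) for cytotoxicity, read by MTT assay, with a stated time of 72 h; a higher number here means a weaker inhibitor, a lower number a stronger inhibitor:

Compound 1 `Cc1ccc(CSc2cc(Cl)c(C)cc2S(=O)(=O)/N=C(\N)n2nc(C)cc2-c2ccccc2)cc1`: 30000 nM
Compound 2 `Cc1cc(-c2ccccc2)n(/C(N)=N/S(=O)(=O)c2cc(C)c(Cl)cc2SCc2ccc(C(F)(F)F)cc2)n1`: 18000 nM
Compound 3 `Cc1cc(-c2ccccc2)n(/C(N)=N/S(=O)(=O)c2cc(C)c(Cl)cc2SCc2ccccc2)n1`: 10000 nM

Compound 3 carries the lowest of these three numbers. Its distance to compound 1 is real: a 3.0-fold lower number from compound 1 to compound 3 (0.48 log units; beyond the scatter). Its distance to compound 2, by contrast, stays inside the usual scatter: a 1.8-fold lower number from compound 2 to compound 3 (0.26 log units; within the scatter). So compound 3 is separated from compound 1 but not clearly from compound 2.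

Compound 4 `Cc1cc(-c2ccccc2)n(/C(N)=N/S(=O)(=O)c2cc(C)c(Cl)cc2SCc2ccc(Cl)cc2)n1` is the next compound to go into this assay. It differs from compound 3 in a single place: chloro in place of hydrogen on an aromatic carbon. The two steps that bear on this change are the ones that put a group onto the same aromatic carbon of compound 3: going to a methyl (the reverse of a 3.0-fold lower number from compound 1 to compound 3 (0.48 log units; beyond the scatter)) raised the number beyond the scatter, and going to a trifluoromethyl (the reverse of a 1.8-fold lower number from compound 2 to compound 3 (0.26 log units; within the scatter)) raised it only within the scatter. Both substitutions moved the number upward, one of them modestly, one of them not convincingly. A chloro at that carbon is therefore expected to give a small upward step, most likely within the scatter: a 1.5-fold higher number from compound 3 to compound 4 (0.18 log units; within the scatter). Compound 4 is thus estimated at 15000 nM, with a plausible range from 7000 nM to 35000 nM.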

Compound 4, half-maximal inhibitory concentration: 11000 nM
For compound 4 the middle estimate is 1.4-fold (0.13 log units) above the measured one; the range from low to high includes it.
By their numbers in this assay, from the lowest: compounds 3, 4, 2 and 1 (each within the scatter of the next, the first and the last beyond it).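

In this assay, chloro on this aromatic carbon cannot be told apart from hydrogen, a 1.1-fold higher number from compound 3 to compound 4 (0.04 log units; within the scatter), so adding a group here does not by itself separate a compound from the plain benzyl one. Chloro also cannot be told apart from trifluoromethyl at the same carbon, a 1.6-fold lower number from compound 2 to compound 4 (0.21 log units; within the scatter), while the step from methyl is modest but clear, a 2.7-fold lower number from compound 1 to compound 4 (0.44 log units; beyond the scatter). Among the four groups at this carbon, methyl now stands apart from both hydrogen and chloro, trifluoromethyl is not clearly separated from any of the other three, and nothing shown here offers an explanation for this.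

The compounds shown leave open whether an amine, a carboxylic acid or a longer alkyl chain on this carbon would group with hydrogen and chloro or with methyl. They also leave open whether chloro on another carbon of this ring would give a reading like the one seen here, and how this change would behave in any test other than this assay.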